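The compounds below may be only part of what the source reports. "The series", "measured", "known", "first", "only" and "open" are said of these compounds alone.

Measured so far:
- compound 1, `NCc1cccc(Cn2c(N)nc3ccccc32)c1`: "not active" (no number reported) in an assay on HEK293 cells for agonist activity at Toll-like receptor 8 (Homo sapiens), read by reporter gene assay; a higher number here means that more compound is needed for the effect, a lower number that less compound is needed
- compound 2, `CCCCCn1c(N)nc2ccc(C)cc21`: 7210 nM
- compound 3, `CCCCCn1c(N)nc2c(Cl)cccc21`: "not active" (no number reported)

Compound 3 carries a chloro group on the ring of its core and shows no number in this assay, only the entry that it is not active. Compound 1, which bears a different substituent pattern on the same kind of core, likewise gives no number. Only compound 2, with a methyl group elsewhere on the core, gives a half-maximal effective concentration, and that value is high. Compound 3 therefore stands among the two entries without a single number, with nothing measured to set it above or below them.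

Compound 4, `CCCCCn1c(N)nc2c([N+](=O)[O-])cccc21`, differs from compound 3 in one place: nitro in place of chloro on an aromatic carbon. Among the measured compounds shown here, no step between measured compounds covers such an exchange, so the direction of any change is open. With compound 3 inactive and compound 2 weak, compound 4 is expected to remain weak or to give no number at all, and its value is estimated at 20000 nM, within a range from 5000 nM to 80000 nM.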

Compound 4, half-maximal effective concentration: "not active" (no number reported)
Compound 4: no number reported; no gap can be computed for the estimate.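

Among the compounds shown here, compound 3 and compound 4 are both entered as not active without a number in this assay, so no step from chloro to nitro can be read. Nothing available bears on this result. The compounds shown leave open whether any group at this place on the shared core gives a measurable value.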